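A few compounds are considered here, and "the series" means these few. Any claim that something is new, unique, unknown or untested is made for them only; others in the source may bear on it.

Working notes on the series.

Going by the values given here, compound 2 `Cc1ccc(-c2ncccn2)c(C(=O)N2CC3(CC3)C[C@H]2CNc2ccc(C(F)(F)F)cn2)n1` gives 8.4 in a functional assay on CHO cells for antagonist activity at Orexin/Hypocretin receptor type 1 (Homo sapiens), read by FLIPR and calcium flux (a lower number here means a less potent compound, a higher number a more potent compound, by a factor of ten per unit of this negative logarithm), the lower of the two numbers so far; the nearest measured neighbour is compound 1 `Cc1ccc(-c2nccs2)c(C(=O)N2CC3(CC3)C[C@H]2CNc2ccc(C(F)(F)F)cn2)n1`, which in this assay gives 8.6. Among the compounds with values here, the only measured step, a number 0.20 log units lower from compound 1 to compound 2 (within the scatter), swaps one six-membered heteroaryl for another and moves nothing beyond the scatter.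

The next compound, compound 3 `Cc1ccc(OCc2ccccc2)c(C(=O)N2CC3(CC3)C[C@H]2CNc2ccc(C(F)(F)F)cn2)n1`, differs from compound 2 by benzyloxy in place of pyrimidin-2-yl on an aromatic carbon, placed ortho to a large group, two atoms from the ring nitrogen and para to a methyl group. Within the data shown here, the one measured step bears on it only loosely: that swap kept an aromatic ring directly on the core, whereas here an oxygen-linked benzyl group enters, so it does not predict the size of the change. Among the measured compounds shown here, with no closer precedent, a modest loss is expected as the more likely outcome, with a wide range on either side.

Compound 3 is therefore estimated at 7.8 in this assay, within 7 to 8.6. This estimate means a step of a number 0.60 log units lower from compound 2 to compound 3 (beyond the scatter) from compound 2, expected to fall somewhat beyond the scatter in the downward direction.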

Compound 3, negative logarithm of the antagonist equilibrium constant: 8.6
For compound 3 the middle estimate is 0.80 log units below the measured one, and the stated range covers the measured number.
By their numbers in this assay, from the lowest: compounds 2, 1 and 3 (each within the scatter of the next).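

The position accepts more than a heteroaryl ring bonded directly to the core: in this assay, the change gives a number 0.20 log units higher from compound 2 to compound 3 (within the scatter) and no change at the digits printed from compound 1 to compound 3 (within the scatter), even though benzyloxy adds an oxygen link and brings a six-membered aromatic ring of carbon only. Across compounds 1, 2 and 3, neither direct attachment of the ring nor ring nitrogen in the group at this position is therefore required to stay within the scatter. No measurement available here accounts for this agreement among the three groups.

The compounds shown leave open whether a group without an aromatic ring, such as an amine or a carboxylic acid, would hold the number at this position. They also leave open whether a longer chain between the oxygen and the aromatic ring would do so.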